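A few compounds are considered here, and "the series" means these few. Any claim that something is new, unique, unknown or untested is made for them only; others in the source may bear on it.

Measured compounds:
compound 1 `COc1cccc(OS(=O)(=O)c2ccc(N3CCN(C)C3=O)cc2)c1`, 1600 nM;
compound 2 `CN1CCN(c2ccc(S(=O)(=O)Oc3cccc(F)c3)cc2)C1=O`, 5800 nM.

In a functional assay on M21 cells (Homo sapiens) for antiproliferative activity, read by sulforhodamine B assay, with a stated time of 48 h (on this read-out lower numbers stand for stronger inhibition and higher numbers for weaker inhibition), compound 2 stands highest of the two numbers shown; its nearest neighbour is compound 1, and the step of a 3.6-fold higher number from compound 1 to compound 2 (0.56 log units; beyond the scatter) separates them. Compound 3 `CN1CCN(c2ccc(S(=O)(=O)Oc3ccc(F)cc3)cc2)C1=O` differs from compound 2 in one place: 4-fluorophenyl in place of 3-fluorophenyl on an oxygen. Among the measured compounds shown here, the single measured step, a 3.6-fold higher number from compound 1 to compound 2 (0.56 log units; beyond the scatter), concerns fluoro in place of methoxy and does not address exchanging 3-fluorophenyl for 4-fluorophenyl, so no measured step bears directly on this change. The author therefore expects a step of a 1.2-fold lower number from compound 2 to compound 3 (0.06 log units; within the scatter) that stays within the scatter. For compound 3 the estimate is 5000 nM, with a range from 1800 nM to 14000 nM.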

Compound 3, half-maximal inhibitory concentration: > 100000 nM
Compound 3 gave a limit, no number; the forecaster's own chance of this, stated with the estimate: 5%; at least 20-fold (1.30 log units) between middle value and limit.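

Among the compounds shown here, on the oxygen bound to the sulfonyl sulfur, the earlier compounds showed only a modest step for exchanging the substituent itself. Here, with the same atoms joined differently, 4-fluorophenyl in place of 3-fluorophenyl gives an at least 17-fold higher number from compound 2 to compound 3 (1.23 log units; beyond the scatter) and is a far larger change, and the comparison with the methoxy compound reads an at least 62-fold higher number from compound 1 to compound 3 (1.79 log units; beyond the scatter) in the same direction. The value of compound 3 is a limit of the assay and not a number: the limit of > 100000 nM in this assay, at which 1 of the 3 values shown sits.

The compounds shown leave open how an unsubstituted phenyl would behave on this oxygen. On these data alone, it also remains open whether a chloro or an amine on that ring would follow 3-fluorophenyl or 4-fluorophenyl.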